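Working notes: 2-cyanobenzyl to 2-bromobenzyl

The source may hold more compounds than are shown below. What is called first, only, known or untested is meant among the compounds shown, and "the series" means these compounds.

- compound 1 `COc1cc(OC)c(-c2coc3cc(OCc4ccc([N+](=O)[O-])cc4)ccc3c2=O)cc1OC` gives 9400 nM
- compound 2 `COc1cc(OC)c(-c2coc3cc(OCc4ccccc4C#N)ccc3c2=O)cc1OC` gives 980 nM

Of the two values in a functional assay on U-251 cells (Homo sapiens) for antiproliferative activity, read by MTT assay, with a stated time of 24 h (a lower number here means a stronger inhibitor, a higher number a weaker inhibitor), the lower belongs to compound 2 at 980 nM and it is the stronger inhibitor of the pair. The next change puts bromo in place of cyano on an aromatic carbon, ortho to a large group, and gives compound 3 `COc1cc(OC)c(-c2coc3cc(OCc4ccccc4Br)ccc3c2=O)cc1OC` (bromo in place of cyano on an aromatic carbon). Within the data shown here, only one measured step bears on this: a 9.6-fold lower number from compound 1 to compound 2 (0.98 log units; beyond the scatter) is modest but beyond the scatter. That step exchanges 4-nitrophenyl for 2-cyanophenyl, so it shows that this part of the molecule can move the number in this assay but does not test bromo. Among the measured compounds shown here, no measured compound carries bromo, so the direction is not settled. For the measured compounds named here, compound 2 holds the lowest value so far (980 nM), so a small rise is the more likely outcome, smaller than the measured step. An estimated move of a 2.0-fold higher number from compound 2 to compound 3 (0.31 log units; beyond the scatter) is expected. The estimate for compound 3 is 2000 nM within an expected range of 600 nM to 7000 nM.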

Compound 3, half-maximal inhibitory concentration: > 10000 nM
Compound 3 was reported as a limit (the forecaster's own chance of this, stated with the estimate: 5%); middle value at least 5.0-fold (0.69 log units) away from the limit.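

In this assay compound 3 gives > 10000 nM, which is a limit of the assay and not a number: the limit of > 10000 nM in this assay, at which 1 of the 3 values shown sits.

The earlier step changed both the group and its place on the phenyl ring, whereas this one keeps the place, an aromatic carbon ortho to a large group, and exchanges only cyano for bromo (an at least 10-fold higher number from compound 2 to compound 3 (1.00 log units; beyond the scatter)). The group at this position therefore matters on its own, and in this pair the low number stays with the nitrile of compound 2, not with the bromo of compound 3. The exchange of 4-nitrophenyl for 2-bromophenyl gives a step whose floor lies within the scatter (an at least 1.0-fold higher number from compound 1 to compound 3 (0.02 log units; that floor lies within the scatter)), so no order is stated between the 4-nitrobenzyl and 2-bromobenzyl compounds.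

The compounds shown do not settle whether the low number of compound 2 is tied to the nitrile itself or would also appear with another group on the same aromatic carbon, such as an amine, a carboxylic acid or a primary amide. They also leave open how far compound 3 lies past its limit, and they give no cause for the step.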